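Swapping hydroxy for amino on the shared core

The source may hold more compounds than are shown below. What is called first, only, known or untested is meant among the compounds shown, and "the series" means these compounds.

Compound 1 `Nc1nc(Cl)c2ncn(C3C=CC(CO)C3)c2n1`: in a functional assay on P388 cells (Mus musculus) for inhibition (a higher number here means that more compound is needed for the effect, a lower number that less compound is needed), compound 1 gives 75 ug/mL.
Compound 2 `Nc1nc(Cl)c2ncn(C3CCC(CO)C3)c2n1`: compound 2 gives > 100 ug/mL, which is a limit of the assay and not a number.
Compound 3 `Nc1nc(O)c2ncn(C3CCC(CO)C3)c2n1`: compound 3 gives > 100 ug/mL, again a limit of the assay.

Compound 3 therefore stands only at a limit, and the same is true of one other value shown (the limit of > 100 ug/mL in this assay, at which 2 of the 3 values shown sit). Going by the values given here, the single step between two measured compounds, a step that the two limits leave unreadable from compound 2 to compound 3, cannot be read because both ends sit at the limit (the limit of > 100 ug/mL in this assay, at which 2 of the 3 values shown sit).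

Compound 4 `Nc1nc(N)c2ncn(C3CCC(CO)C3)c2n1` differs from compound 3 by amino in place of hydroxy on an aromatic carbon.

Among the compounds with values here, no measured step bears directly on this change, and the one step known is unreadable. With nothing pointing to a gain, compound 4 is expected to stay near the limit, a step that the limit leaves unreadable from compound 3 to compound 4. The estimate for compound 4 is 150 ug/mL, within a range from 40 ug/mL to 600 ug/mL.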

Compound 4, concentration for half-maximal effect: 80 ug/mL
Compound 4: the middle estimate sits 1.9-fold (0.27 log units) above what was measured, within the range that was stated.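

On the shared core of compound 4, amino on this aromatic carbon next to the ring nitrogen is the first group shown to give a number instead of a limit in this assay. The change from hydroxy gives an at least 1.2-fold lower number from compound 3 to compound 4 (0.09 log units; that floor lies within the scatter), and the change from chloro gives an at least 1.2-fold lower number from compound 2 to compound 4 (0.09 log units; that floor lies within the scatter). Neither floor separates amino from the group it replaces, and the true size of each step stays hidden: the limit of > 100 ug/mL in this assay, at which 2 of the 4 values shown sit.

The compounds shown leave open how a methylamino or a methoxy group would read at this position.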